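Estimating Compound 4 After Swapping Chloro for Methoxy

The compounds below may be only part of what the source reports. "The series", "measured", "known", "first", "only" and "open" are said of these compounds alone.

Three compounds that share one core have been examined in an ADME assay on Vero cells (Chlorocebus sabaeus) for cytotoxicity, read by neutral red uptake, tested at 787 ug/mL; a higher number here means a weaker effect of the compound at the concentration tested, a lower number a stronger effect. Compound 1 `O=C1CSC(c2ccc(Cl)cc2)N1CCN1CCCCC1` gives 15%, the second highest of the three numbers. Compound 3 `O=C1CSC(c2c(Cl)cccc2Cl)N1CCN1CCCCC1` gives 11%, which lies within the scatter of compound 1, so these two cannot be ranked against each other. Compound 2 `O=C1CSC(c2ccccc2Cl)N1CCN1CCCCC1` gives 38%; the step of a number 23 percentage points higher from compound 1 to compound 2 (beyond the scatter) lies beyond the scatter, as does a number 27 percentage points lower from compound 2 to compound 3 (beyond the scatter). Both measured steps concern only chloro groups on aromatic carbons, and neither involves a methoxy group.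

Compound 4 `COc1ccc(C2SCC(=O)N2CCN2CCCCC2)cc1` differs from compound 1 by methoxy in place of chloro on an aromatic carbon. Among the compounds with values here, no measured step bears directly on this exchange, and the chloro rearrangements seen so far moved the read-out only modestly, in both directions. Accordingly the expected step is a number 5 percentage points higher from compound 1 to compound 4 (within the scatter), which stays within the scatter. Compound 4 is estimated at 20% in this assay. The likely range for compound 4 runs from 5% to 45%.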

Compound 4, a percentage reported as activity, at one concentration (the size of the read-out at that concentration, not a potency): 33%
Beside the measured number, compound 4's estimate is 13 percentage points below it; the measured number falls inside the stated range.
By their numbers in this assay, from the lowest: compounds 3 and 1 (each within the scatter of the next); then compounds 4 and 2 (each within the scatter of the next).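

The exchange gives a number 18 percentage points higher from compound 1 to compound 4 (beyond the scatter) in this assay and so shows that the read-out responds to the kind of group on this aromatic carbon, para to a large group. The earlier steps shown here only moved or added chloro, whereas this one replaces chloro with a different group, and the higher number here means a weaker effect at the concentration tested. No measurement at hand gives a cause for this step.

As far as these compounds go, whether the higher number comes from methoxy itself or simply from the loss of chloro stays open, and a plain hydrogen, a methyl or an amine on this same carbon would help separate the two. Also open, from the compounds shown here alone, is how methoxy would behave on the other aromatic carbons that carry chloro in compound 2 and compound 3.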